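This account rests on a few compounds, and the source may have more. Where it says the series, first, only, none or still open, it means among the compounds named here.

Working notes on the series. Compound 1 `O=Cc1c(-c2ccc([N+](=O)[O-])cc2)nc2sc(Cc3ccccc3)nn12` carries a formyl group on the shared core and a nitro group on the pendant phenyl ring. Among the measured compounds shown here, in a functional assay on cells (Leukemia cell, Homo sapiens) for inhibition (a higher number here means a weaker inhibitor of growth, a lower number a stronger inhibitor of growth), compound 1 gives 5900 nM, the lowest of the two numbers so far. For the measured compounds named here, compound 2 `O=[N+]([O-])c1ccc(-c2nc3sc(Cc4ccccc4)nn3c2Br)cc1` is the only other measured member; in this assay compound 2 gives 69200 nM. Going by the values given here, the one measured step, a 12-fold higher number from compound 1 to compound 2 (1.07 log units; beyond the scatter), exchanges the formyl group on the core and nothing else.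

Compound 3 `O=Cc1c(-c2ccc(Br)cc2)nc2sc(Cc3ccccc3)nn12` is not yet measured. The change from compound 1 is bromo in place of nitro on an aromatic carbon. Among the compounds with values here, no measured step bears directly on this exchange: the step from compound 1 to compound 2 alters a different group at a different place, so it shows only that a single exchange can shift this assay well beyond the scatter, without telling the direction for the present change. The formyl group, which stays, is the group whose loss coincided with the large step on record.

In the absence of a comparable step, the expected change is modest, a 1.4-fold higher number from compound 1 to compound 3 (0.13 log units; within the scatter), with wide uncertainty. Compound 3 is therefore estimated at 8000 nM, in the range 2500 nM to 30000 nM.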

Compound 3, concentration for 50% growth inhibition: 1410 nM
Compound 3: the middle estimate sits 5.7-fold (0.75 log units) above what was measured; the measured number lies below the stated range.
By their numbers in this assay, from the lowest: compound 3; then compound 1; then compound 2.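

The pendant phenyl ring is now shown to be a place where a single exchange moves this assay beyond the scatter: bromo in place of nitro on an aromatic carbon, para to a large group, gives a 4.2-fold lower number from compound 1 to compound 3 (0.62 log units; beyond the scatter), with the formyl group on the core unchanged. The nitro group is thus not needed for growth inhibition in this pair, and the direction runs opposite to that of the earlier step at the core, a 12-fold higher number from compound 1 to compound 2 (1.07 log units; beyond the scatter), although the two steps alter different groups at different places. Nothing in hand bears on what lies behind the lower number, so the exchange stays an observation without an assigned cause.

From the compounds shown here alone, with only nitro and bromo compared at this place, it remains open whether the lower number is particular to bromo or would extend to chloro, methoxy, an amine or a carboxylic acid. It is also open whether the exchange would keep its direction and size with bromo rather than formyl on the core, since the compounds shown hold bromo on the phenyl ring only together with the formyl group.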